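Notes on aryloxyethylamines in the serotonin 1B assay

The source may report more compounds than this note shows. Statements on the series, on what has been measured and on what is new or still open speak of the compounds shown alone.

Measured so far:
compound 1 `CN(C)CCCCOc1cccc2ccccc12`: 470 nM
compound 2 `OCCNCCOc1cccc2ccccc12`: 107 nM

In a functional assay for agonist activity at 5-hydroxytryptamine receptor 1B (Homo sapiens) (a higher number here means a weaker inhibitor, a lower number a stronger inhibitor), compound 2 gives 107 nM, the lowest of the two numbers in hand. Among the compounds with values here, the only measured step, a 4.4-fold lower number from compound 1 to compound 2 (0.64 log units; beyond the scatter), is modest and beyond the scatter; it changes the chain and the groups on the nitrogen at once.

Compound 3 `CC(C)NCCOc1cccc2ccccc12` differs from compound 2 by isopropyl in place of 2-hydroxyethyl on an amine nitrogen. Within the data shown here, no measured step alters only the substituent on the amine nitrogen, so the step of a 4.4-fold lower number from compound 1 to compound 2 (0.64 log units; beyond the scatter) bears on this change only loosely, and no direction can be read from it. In this assay compound 3 is therefore expected to stay within the scatter of compound 2, with a 1.4-fold higher number from compound 2 to compound 3 (0.15 log units; within the scatter) as the estimated step. The estimate for compound 3 in this assay is 150 nM, with a range of 50 nM to 450 nM.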

Compound 3, inhibition constant: 120 nM
Compound 3: middle estimate off by 1.3-fold (0.10 log units), on the high side; the measured number falls inside the stated range.
By their numbers in this assay, from the lowest: compounds 2 and 3 (each within the scatter of the next); then compound 1.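

In this assay, within the data shown here, the step of a 1.1-fold higher number from compound 2 to compound 3 (0.05 log units; within the scatter) is the first to alter only the substituent on the amine nitrogen, and it lies within the scatter even though isopropyl carries neither the hydrogen-bond donor nor the hydrogen-bond acceptor counted on 2-hydroxyethyl. The step of a 3.9-fold lower number from compound 1 to compound 3 (0.59 log units; beyond the scatter) lies beyond the scatter, so compound 3 also stands apart from compound 1, but this step again changes the chain and the nitrogen groups at once and cannot be divided between them. Nothing in hand gives a cause for these results.

Whether the chain or the dimethylamino group accounts for the distance from compound 1 remains open. Also open, from the compounds shown here alone, is how a benzyl or tert-butyl group on this nitrogen, or an unsubstituted primary amine, would read.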